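Swapping iodo for fluoro on a shared urea-linked core

The compounds below may be only part of what the source reports. "The series", "measured", "known", "first", "only" and "open" are said of these compounds alone.

Measured so far:
Compound 1, `Cc1nc2ccccc2c(=O)n1NC(=O)Nc1ccc(Cl)cc1`: 48%
Compound 2, `Cc1ccccc1NC(=O)Nn1c(C)nc2ccccc2c1=O`: 51%
Compound 3, `Cc1nc2ccccc2c(=O)n1NC(=O)Nc1ccc(I)cc1`: 53%

All three compounds were tested in a functional assay on the whole organism for inhibition, with Mus musculus as the target, with a stated time of 1 h, at a dose of 100 mg/kg by the intraperitoneal route; a lower number here means less inhibition, a higher number more inhibition at the dose given (going by the name of the read-out). In this assay compound 3 gives 53%, the highest of the three numbers, though only just: the step of a number 2 percentage points higher from compound 2 to compound 3 (within the scatter) and the step of a number 5 percentage points higher from compound 1 to compound 3 (within the scatter) both stay within the scatter, so the three compounds cannot be ranked.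

Compound 4, `Cc1nc2ccccc2c(=O)n1NC(=O)Nc1ccc(F)cc1`, has not been measured yet. It differs from compound 3 by fluoro in place of iodo on an aromatic carbon. For the measured compounds named here, the one measured step that bears on this kind of swap, a halogen on the same aromatic carbon exchanged for another halogen, is a number 5 percentage points higher from compound 1 to compound 3 (within the scatter), which lies within the scatter. The other two steps, a number 3 percentage points higher from compound 1 to compound 2 (within the scatter) and a number 2 percentage points higher from compound 2 to compound 3 (within the scatter), are likewise within the scatter. Going from compound 3 to compound 4 is therefore expected to change this assay by no more than the scatter, as a number 3 percentage points lower from compound 3 to compound 4 (within the scatter). Compound 4 is estimated to give 50% in this assay, within a range from 38% to 62%.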

Compound 4, a percentage reported as inhibition, in the whole organism at one dose (the size of the read-out at that dose, not a potency): 45%
Estimate against measurement, compound 4: 5 percentage points above, within the range that was stated.
By their numbers in this assay, from the lowest: compounds 4, 1, 2 and 3 (each within the scatter of the next).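

With fluoro, the para position on the aromatic ring now carries three different halogens in this assay, and neither exchange involving fluoro stands out: the result is a number 8 percentage points lower from compound 3 to compound 4 (within the scatter) for iodo and a number 3 percentage points lower from compound 1 to compound 4 (within the scatter) for chloro. Replacing the whole aryl group gives a number 6 percentage points lower from compound 2 to compound 4 (within the scatter) and likewise leaves 4-fluorophenyl and 2-methylphenyl indistinguishable, so none of the changes shown at this end of the urea can be separated from ordinary variation between repeated measurements. Nothing measured here offers an explanation for these numbers.

The compounds shown leave open whether a quite different group at this position, such as an amine or a carboxylic acid, would produce a step beyond the scatter. They also leave open how a change to the shared core, such as a longer chain in place of its methyl group, would affect the read-out.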